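From Compound 3 to Compound 4: Methoxy Replaces Chloro

A few compounds are considered here, and "the series" means these few. Any claim that something is new, unique, unknown or untested is made for them only; others in the source may bear on it.

Of the compounds shown here, three have been measured in a functional assay on the whole organism (strain albino) for inhibition, with Rattus norvegicus as the target, read by paw edema, with stated times of 30 min and 2 h, at a dose of 100 mg/kg by the oral route; a lower number here means less inhibition, a higher number more inhibition at the dose given (going by the name of the read-out). Compound 1 `COc1ccc(/C=C/C(=O)c2ccc(NC(=O)CBr)cc2)cc1` gives 42%, compound 2 `COc1ccc(/C=C/C(=O)c2ccc(NC(=O)CO[N+](=O)[O-])cc2)cc1` gives 49%, and compound 3 `CC(Br)C(=O)Nc1ccc(C(=O)/C=C/c2ccc(Cl)cc2)cc1` gives 45%. On these numbers compound 3 stands second highest of the three: its nearest neighbour is compound 1, whose number is lower by an amount within the scatter, and its furthest is compound 2, whose number is higher by an amount that is also within the scatter. Within the data shown here, the only step measured between two compounds that differ in one place is a number 7 percentage points higher from compound 1 to compound 2 (within the scatter), and it concerns the saturated chain carbon bound to the carbonyl carbon, not the aromatic ring.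

Compound 4 `COc1ccc(/C=C/C(=O)c2ccc(NC(=O)C(C)Br)cc2)cc1` is not yet measured. It differs from compound 3 by methoxy in place of chloro on an aromatic carbon, which, cut one bond further out, reads 4-chlorophenyl to 4-methoxyphenyl. Among the measured compounds shown here, no measured step bears on this exchange, and all three measured numbers sit within the scatter of one another, so no step beyond the scatter is expected in this assay. The step of no change at the digits printed from compound 3 to compound 4 (within the scatter) is therefore expected to be small. Compound 4 is estimated at 45%, within a range from 33% to 57%.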

Compound 4, a percentage reported as inhibition, in the whole organism at one dose (the size of the read-out at that dose, not a potency): 40%
The estimate for compound 4 lay 5 percentage points above the measured number; the measured number falls inside the stated range.
By their numbers in this assay, from the lowest: compounds 4, 1, 3 and 2 (each within the scatter of the next).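

In this assay, among these compounds, the exchange of chloro for methoxy on an aromatic carbon para to a large group gives a number 5 percentage points lower from compound 3 to compound 4 (within the scatter) and is the only step here that bears on this position, so at this dose the two groups cannot be told apart. The steps on the other side of the molecule read the same way, with methyl in place of hydrogen on the saturated chain carbon giving a number 2 percentage points lower from compound 1 to compound 4 (within the scatter) and 1-bromoethyl in place of (nitrooxy)methyl on the carbonyl carbon giving a number 9 percentage points lower from compound 2 to compound 4 (within the scatter), so neither the ring position nor the chain has yet produced a step beyond the scatter. No measurement offered here accounts for any of these steps.

As far as these compounds go, whether an amine or a carboxylic acid on this aromatic carbon, or a longer chain in place of the methyl on the carbon bearing bromine, would move the number beyond the scatter remains open. With one dose as the only read-out, these numbers also leave open how the compounds would compare at other doses.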